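This account rests on a few compounds, and the source may have more. Where it says the series, first, only, none or still open, it means among the compounds named here.

Measured so far in a physicochemical assay for lipophilicity; a higher number here means a more lipophilic compound, a lower number a more polar compound:
- compound 1 `Cc1cn(C2CC(N=[N+]=[N-])C(COC(=O)OCCCC(=O)OC(C)(C)C)O2)c(=O)[nH]c1=O` gives 1.14
- compound 2 `Cc1cn(C2CC(N=[N+]=[N-])C(COC(=O)OCCCN)O2)c(=O)[nH]c1=O` gives -0.93
- compound 3 `Cc1cn(C2CC(N=[N+]=[N-])C(COC(=O)CCCC(=O)OC(C)(C)C)O2)c(=O)[nH]c1=O` gives 1.17

Compound 1 and compound 3 have values within the scatter of each other; the difference between their two cores is not broken down here. The change amino in place of tert-butoxycarbonyl on a saturated chain carbon, three bonds along the chain from an oxygen next to a carbonyl group produced the step of a number 2.07 log units lower from compound 1 to compound 2 (beyond the scatter), and the reverse direction appears as a number 2.10 log units higher from compound 2 to compound 3 (beyond the scatter).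

Compound 4 `Cc1cn(C2CC(N=[N+]=[N-])C(COC(=O)CCCN)O2)c(=O)[nH]c1=O` is not yet measured. It carries the change (amino in place of tert-butoxycarbonyl on a saturated chain carbon, three bonds along the chain from a carbonyl carbon). This is the same kind of change as from compound 1 to compound 2, not the same: there the place is three bonds along the chain from an oxygen next to a carbonyl group, here three bonds along the chain from a carbonyl carbon. For the measured compounds named here, a step of similar size is expected, a number 2.07 log units lower from compound 3 to compound 4 (beyond the scatter), because the only precedent is a number 2.07 log units lower from compound 1 to compound 2 (beyond the scatter). Compound 4 is therefore estimated at -0.9, between -1.5 and -0.3.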

Compound 4, partition coefficient: -0.9
Beside the measured number, compound 4's estimate shows no gap at the digits printed; measured number inside the range.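

In this assay, amino in place of tert-butoxycarbonyl gives a large step on both cores (a number 2.07 log units lower from compound 3 to compound 4 (beyond the scatter)) and (a number 2.07 log units lower from compound 1 to compound 2 (beyond the scatter)), and the two steps print the same size, so here the change carries from one core to the other. With the amino end on both chains, the 3-aminopropyl and 3-aminopropoxy forms stay within the scatter (a number 0.03 log units higher from compound 2 to compound 4 (within the scatter)). For the compounds shown here, this is only one pair of cores and one pair of groups, so it gives no general rule, and no evidence here bears on why the step has this size.

The compounds shown leave open whether the same step holds for other end groups, such as a carboxylic acid or a dimethylamino group. They also leave open whether it holds on a longer chain.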